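Chlorophenyl in place of dimethylphenyl on the shared core

A few compounds are considered here, and "the series" means these few. Any claim that something is new, unique, unknown or untested is made for them only; others in the source may bear on it.

In a functional assay on BGC-823 cells (Homo sapiens) for inhibition, read by CCK-8 assay, with a stated time of 48 h (a lower number here means a stronger inhibitor, a higher number a weaker inhibitor), compound 1 (`Cc1ccc(C2=NN(C3=NC(=O)CS3)C(c3ccc4ccccc4c3)C2)cc1`) gives 7790 nM as its half-maximal inhibitory concentration, compound 2 (`O=C1CSC(N2N=C(c3ccc(Br)cc3)CC2c2ccc3ccccc3c2)=N1`) gives 11700 nM and compound 3 (`Cc1ccc(C2=NN(C3=NC(=O)CS3)C(c3ccc4ccccc4c3)C2)cc1C`) gives 6020 nM on the same read-out. Compound 3 cannot be separated from the other two, as both of its steps stay within the scatter: a 1.3-fold lower number from compound 1 to compound 3 (0.11 log units; within the scatter) and a 1.9-fold lower number from compound 2 to compound 3 (0.29 log units; within the scatter) in the same assay.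

The next change leads to compound 4 (`O=C1CSC(N2N=C(c3ccc(Cl)cc3)CC2c2ccc3ccccc3c2)=N1`), with 4-chlorophenyl in place of 3,4-dimethylphenyl on a carbon with a double bond to nitrogen. Within the data shown here, no chlorinated compound has been measured, so the closest evidence is the 4-bromophenyl group of compound 2. The most direct precedent is a 1.9-fold lower number from compound 2 to compound 3 (0.29 log units; within the scatter) for a swap at this same carbon, and bromo in place of methyl gave a 1.5-fold higher number from compound 1 to compound 2 (0.18 log units; within the scatter) in a similar comparison. All three measured steps remain within the scatter, so no step beyond the scatter is expected in this assay, and no direction can be claimed with confidence. The expected change is small (a 1.5-fold higher number from compound 3 to compound 4 (0.17 log units; within the scatter)) and does not exceed the scatter. For compound 4 the estimated value is 9000 nM with an expected range of 5000 nM to 16000 nM in this series.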

Compound 4, half-maximal inhibitory concentration: 13200 nM
For compound 4 the middle estimate is 1.5-fold (0.17 log units) below the measured one, and the stated range covers the measured number.
By their numbers in this assay, from the lowest: compounds 3, 1, 2 and 4 (each within the scatter of the next, the first and the last beyond it).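

Within this assay, the swap at the carbon with a double bond to nitrogen gives the first step in the series beyond the scatter, though a modest one: a 2.2-fold higher number from compound 3 to compound 4 (0.34 log units; beyond the scatter) for 4-chlorophenyl in place of 3,4-dimethylphenyl. Among these compounds, this separation stands alone, as the halogen exchange on the aromatic carbon cannot be resolved (a 1.1-fold higher number from compound 2 to compound 4 (0.05 log units; within the scatter)), and neither can chloro in place of methyl (a 1.7-fold higher number from compound 1 to compound 4 (0.23 log units; within the scatter)), so the compounds with a single group on this phenyl ring remain one cluster, and only the pair of compound 3 and compound 4 is separated. Nothing available bears on why this one exchange clears the scatter while the others do not.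

A 4-methoxyphenyl, 4-aminophenyl or 4-carboxyphenyl group on this carbon would test whether the series can move further than this narrow band, since the groups shown here are limited to methyl and halogen substituents. Also open, from the compounds shown here alone, is whether a 3-chloro-4-methylphenyl group would follow compound 3 or compound 4, and whether this modest step would hold with a different large group on the shared core.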